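The source may hold more compounds than are shown below. What is called first, only, known or untested is meant among the compounds shown, and "the series" means these compounds.

Three compounds have been measured in an in vitro assay on 293-EBNA cells for binding affinity to corticotropin-releasing factor receptor 1 (Homo sapiens); a higher number here means a weaker inhibitor, a lower number a stronger inhibitor:

Compound 1 `CCCCN(CC)c1nc(C)nc2c1ncn2-c1ccc(C(C)C)cc1Br` gives 4.3 nM
Compound 2 `CCCCN(CC)c1nc(C)nc2c1nc(C)n2-c1ccc(C(C)C)cc1Br` gives 0.9 nM
Compound 3 `CCCCN(CC)c1nc(C)nc2c1nc(C(F)(F)F)n2-c1ccc(C(C)C)cc1Br` gives 1.4 nM

Compound 1 stands highest of the three numbers; the nearer step away from it is a 3.1-fold lower number from compound 1 to compound 3 (0.49 log units; beyond the scatter), the further one a 4.8-fold lower number from compound 1 to compound 2 (0.68 log units; beyond the scatter), and between those two the step is a 1.6-fold higher number from compound 2 to compound 3 (0.19 log units; within the scatter). Compound 4 `CCC(CC)Oc1nc(C)nc2c1ncn2-c1ccc(C(C)C)cc1Br` differs from compound 1 by (pentan-3-yl)oxy in place of butyl(ethyl)amino on an aromatic carbon. Among the compounds with values here, every measured step alters a hydrogen or a small group on a different aromatic carbon, and none touches the butyl(ethyl)amino group, so no measured step bears on this change. The expectation therefore rests on compound 1 alone, and a step of a 2.3-fold higher number from compound 1 to compound 4 (0.37 log units; beyond the scatter) is estimated, with a wide margin. Compound 4 is expected to give 10 nM, within a range from 2 nM to 50 nM.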

Compound 4, inhibition constant: 3.5 nM
Compound 4: middle estimate off by 2.9-fold (0.46 log units), on the high side; the measured number falls inside the stated range.
By their numbers in this assay, from the lowest: compounds 2 and 3 (each within the scatter of the next); then compounds 4 and 1 (each within the scatter of the next).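

In this assay, putting (pentan-3-yl)oxy in place of butyl(ethyl)amino gives a 1.2-fold lower number from compound 1 to compound 4 (0.09 log units; within the scatter), so the two compounds cannot be told apart. Within the data shown here, this is the first view of this position, and it shows that the oxygen-linked branched chain can stand there as well as the nitrogen-linked one, at least on this core. Nothing available explains this match.

Still open, from the compounds shown here alone, is how a methoxy group, a free amine or a longer chain would fare on this carbon. Going by these compounds, it is also open whether the methyl and trifluoromethyl steps seen from compound 1 would carry over to compound 4.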